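Chain Extension on the Core Nitrogen of Compound 2

The source may report more compounds than this note shows. Statements on the series, on what has been measured and on what is new or still open speak of the compounds shown alone.

Measured compounds:
compound 1 `CCCCn1c(CCC)nc2cc(N)ccc21` gives 18200000 nM in a functional assay, read by spectrophotometry, in phosphate buffer, with a stated time of 20 min, at pH 6.6; on this read-out higher numbers stand for an effect only at larger amounts of compound and lower numbers for an effect already at smaller amounts
compound 2 `CCCCCn1c(CCC)nc2cc(N)ccc21` gives 10200000 nM in this assay
compound 3 `CCCCCn1c(CCC)nc2cc(NS(C)(=O)=O)ccc21` gives 3700000 nM in this assay

Compound 2 stands second highest of the three numbers: its step from compound 1 is a 1.8-fold lower number from compound 1 to compound 2 (0.25 log units; within the scatter), and its step to compound 3 is a 2.8-fold lower number from compound 2 to compound 3 (0.44 log units; beyond the scatter). Compound 4 `CCCCCCn1c(CCC)nc2cc(N)ccc21` differs from compound 2 by methyl in place of hydrogen on a saturated chain carbon, five bonds along the chain from an aromatic nitrogen. Among the measured compounds shown here, the only measured step that bears on this is the one from compound 1 to compound 2, which shows a 1.8-fold lower number from compound 1 to compound 2 (0.25 log units; within the scatter); it also added a methyl on the same chain, one bond nearer the aromatic nitrogen. The step to compound 4 is therefore expected to be small, at most a slight lowering, in this assay, estimated as a 1.5-fold lower number from compound 2 to compound 4 (0.16 log units; within the scatter). Compound 4 is expected to give about 7000000 nM, between 3000000 nM and 16000000 nM.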

Compound 4, half-maximal effective concentration: 10300000 nM
Compound 4: the middle estimate sits 1.5-fold (0.17 log units) below what was measured; the measured number falls inside the stated range.
By their numbers in this assay, from the lowest: compound 3; then compounds 2, 4 and 1 (each within the scatter of the next).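

In this assay methyl in place of hydrogen on a saturated chain carbon, five bonds along the chain from an aromatic nitrogen, gives a 1.0-fold higher number from compound 2 to compound 4 (0.00 log units; within the scatter) and so leaves no readable effect at this position. Even the ethyl change, taken four bonds along the chain, gives a 1.8-fold lower number from compound 1 to compound 4 (0.25 log units; within the scatter) and so the whole extension stays within the scatter in this assay as well. Nothing measured here accounts for this result.

Going by these compounds, whether a longer chain or a carboxylic acid at this position would shift the number remains open. So does whether methylsulfonyl, which gave a 2.8-fold lower number from compound 2 to compound 3 (0.44 log units; beyond the scatter) on the shorter chain, would act the same way on compound 4.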